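Swapping Chloro for Bromo on the Aryl Ether

The compounds below may be only part of what the source reports. "The series", "measured", "known", "first", "only" and "open" are said of these compounds alone.

Measured compounds:
- compound 1 `NC1=NC2(CCSCC2)N(OCCCOc2cccc(Cl)c2)C(N)=N1`: 60 nM
- compound 2 `NC1=NC2(CCOCC2)N(OCCCOc2ccc(Cl)cc2)C(N)=N1`: 360 nM
- compound 3 `NC1=NC2(CCOCC2)N(OCCCOc2cccc(Cl)c2Cl)C(N)=N1`: 100 nM

In a functional assay on A549 cells (Homo sapiens) for antiproliferative activity, read by MTT assay, with a stated time of 72 h (on this read-out higher numbers stand for weaker inhibition and lower numbers for stronger inhibition), compound 2 gives 360 nM, the highest number of the three, so it is the weakest inhibitor of this small set. Compound 3 gives 100 nM and compound 1 gives 60 nM in this assay, both clearly lower.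

Compound 4 `NC1=NC2(CCOCC2)N(OCCCOc2ccc(Br)cc2)C(N)=N1` has not yet been measured. It differs from compound 2 in one place: bromo in place of chloro on an aromatic carbon. Within the data shown here, the only measured step that starts from compound 2 is a 3.6-fold lower number from compound 2 to compound 3 (0.56 log units; beyond the scatter), and that step concerns a different change, the addition of a second chloro with a shift of the first, not an exchange of one halogen for another. Among the measured compounds shown here, no measured pair shows what a chloro-to-bromo swap does here. Since the change keeps the same kind of substituent at the same position, the expected step of a 1.4-fold lower number from compound 2 to compound 4 (0.16 log units; within the scatter) is small, most likely within the scatter, perhaps leaning slightly toward stronger inhibition. Compound 4 is therefore estimated at 250 nM in this assay, with a range from 100 nM to 600 nM.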

Compound 4, half-maximal inhibitory concentration: 280 nM
Compound 4: middle estimate off by 1.1-fold (0.05 log units), on the low side, within the range that was stated.
By their numbers in this assay, from the lowest: compounds 1 and 3 (each within the scatter of the next); then compounds 4 and 2 (each within the scatter of the next).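

In this assay, bromo in place of chloro on this aromatic carbon gives a 1.3-fold lower number from compound 2 to compound 4 (0.11 log units; within the scatter), so this first direct exchange of one halogen for another produces no difference that can be told apart from the scatter. By contrast, a 2.8-fold higher number from compound 3 to compound 4 (0.45 log units; beyond the scatter) is a step beyond the scatter, with 4-bromophenyl in place of 2,3-dichlorophenyl, so among compounds 2, 3 and 4 the aryl pattern matters more than the choice between these two halogens on the same carbon. Nothing shown here gives a reason for either step.

Still open, from the compounds shown here alone, is what a group of another kind on this carbon, such as an amine or a carboxylic acid, would do to the number. Going by these compounds, it is also open whether the same exchange would stay as small on the core of compound 1.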